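Swapping the Sulfonyl Aryl Group: Expected Effect on Cell Growth

The source may report more compounds than this note shows. Statements on the series, on what has been measured and on what is new or still open speak of the compounds shown alone.

Of the compounds shown here, three built on a shared core have been measured in an ADME assay on HEK-293T cells (Homo sapiens) for inhibition, read by CCK-8 assay, with a stated time of 48 h, tested at 20 uM (a lower number here means less inhibition of growth, a higher number more inhibition of growth at the concentration tested), and a fourth, compound 4 with structure `N#C/C(=C\c1ccccc1OS(=O)(=O)c1ccc(Cl)cc1)C(=O)Nc1nnc(Cc2ccc(Cl)cc2)s1`, awaits its result.

Compound 1, `COc1ccc(Cc2nnc(NC(=O)/C(C#N)=C/c3ccccc3OS(=O)(=O)c3ccccc3[N+](=O)[O-])s2)cc1`, gives 18% in this assay. Compound 2, `COc1ccc(Cc2nnc(NC(=O)/C(C#N)=C/c3ccccc3OS(=O)(=O)c3ccc(Cl)cc3)s2)cc1`, differs from compound 1 by 4-chlorophenyl in place of 2-nitrophenyl on a sulfonyl sulfur, and in this assay compound 2 gives 34%, which is a number 16 percentage points higher from compound 1 to compound 2 (beyond the scatter). Compound 3, `N#C/C(=C\c1ccccc1OS(=O)(=O)c1ccccc1[N+](=O)[O-])C(=O)Nc1nnc(Cc2ccc(Cl)cc2)s1`, differs from compound 1 in its core by chloro in place of methoxy on an aromatic carbon, and in this assay compound 3 gives 20%, which is a number 2 percentage points higher from compound 1 to compound 3 (within the scatter). Compound 1 and compound 3 therefore behave alike in this measurement.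

Compound 4 differs from compound 3 by 4-chlorophenyl in place of 2-nitrophenyl on a sulfonyl sulfur, the same change as that from compound 1 to compound 2, at a place described in the same words. This change occurs two times among these compounds, once with both ends measured and once not. Among the measured compounds shown here, the step expected here is a number 14 percentage points higher from compound 3 to compound 4 (beyond the scatter), because the one measured example of this change gave a number 16 percentage points higher from compound 1 to compound 2 (beyond the scatter), and the two starting points, compound 1 and compound 3, sit close together. In this assay compound 4 is accordingly estimated at 34%, with a range from 20% to 48%. Since this expectation rests on a single earlier example, it is held loosely.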

Compound 4, percent growth inhibition at one concentration: 14%
For compound 4 the middle estimate is 20 percentage points above the measured one; the whole stated range lies above it.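

On the core of compound 3, putting 4-chlorophenyl in place of 2-nitrophenyl on the sulfonyl sulfur gives a number 6 percentage points lower from compound 3 to compound 4 (within the scatter) in this assay, so the change does not carry its result over from the core of compound 1: the same change on two cores in this assay, a number 16 percentage points higher (beyond the scatter) from compound 1 to compound 2 and a number 6 percentage points lower (within the scatter) from compound 3 to compound 4, 22 percentage points apart, beyond the scatter of two such steps. Seen from the other side of the same four compounds, chloro in place of methoxy on an aromatic carbon gives a number 20 percentage points lower from compound 2 to compound 4 (beyond the scatter), and this change also differs with its surroundings: the same change on two cores in this assay, a number 2 percentage points higher (within the scatter) from compound 1 to compound 3 and a number 20 percentage points lower (beyond the scatter) from compound 2 to compound 4, 22 percentage points apart, beyond the scatter of two such steps. So in these four compounds the two changes do not add up as separate contributions, since what one does depends on which partner group is present, but this rests on a single pair for each step and does not show why the steps differ or what the swap would do on any further core.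

The compounds shown leave open whether this dependence is tied to these particular groups, or would also appear with an unsubstituted phenyl or a 4-methylphenyl on the sulfonyl sulfur. They also leave open what a fluoro or a methyl would do in place of the chloro or methoxy on the aromatic carbon, on either sulfonyl partner.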